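A methyl added to the aryl ether of compound 2

This account rests on a few compounds, and the source may have more. Where it says the series, first, only, none or still open, it means among the compounds named here.

Compound 2 `CC[C@@H]1/C=C(\C)C[C@H](C)C[C@H](OC)[C@H]2O[C@@](O)(C(=O)C(=O)N3CCCC[C@H]3C(=O)O[C@H](/C(C)=C/[C@@H]3CC[C@@H](Oc4ccccc4)[C@H](O)C3)[C@H](C)[C@@H](O)CC1=O)[C@H](C)C[C@@H]2OC` gives 5.2 nM in a functional assay on cells for inhibition, with Murine T-cell line (Mus musculus) as the target; on this read-out higher numbers stand for weaker inhibition and lower numbers for stronger inhibition; of the two compounds measured, it has the highest number. Compound 1 `CC[C@@H]1/C=C(\C)C[C@H](C)C[C@H](OC)[C@H]2O[C@@](O)(C(=O)C(=O)N3CCCC[C@H]3C(=O)O[C@H](/C(C)=C/[C@@H]3CC[C@@H](Oc4ccc(C)cc4)[C@H](OC)C3)[C@H](C)[C@@H](O)CC1=O)[C@H](C)C[C@@H]2OC` gives 2.7 nM, which lies within the usual scatter of compound 2. Compound 3 `CC[C@@H]1/C=C(\C)C[C@H](C)C[C@H](OC)[C@H]2O[C@@](O)(C(=O)C(=O)N3CCCC[C@H]3C(=O)O[C@H](/C(C)=C/[C@@H]3CC[C@@H](Oc4ccc(C)cc4)[C@H](O)C3)[C@H](C)[C@@H](O)CC1=O)[C@H](C)C[C@@H]2OC` is not yet measured. It differs from compound 2 by methyl in place of hydrogen on an aromatic carbon, a change on an aromatic carbon of a six-membered aromatic ring of carbon only, para to a large group. For the measured compounds named here, no measured pair isolates this change, so a step no larger than the scatter is expected, if anything toward a lower number, as the value of compound 1 hints. Compound 3 is therefore estimated at 3.5 nM, between 1.5 nM and 8 nM, a step of a 1.5-fold lower number from compound 2 to compound 3 (0.17 log units; within the scatter).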

Compound 3, half-maximal inhibitory concentration: 6 nM
Beside the measured number, compound 3's estimate is 1.7-fold (0.23 log units) below it; the range from low to high includes it.
By their numbers in this assay, from the lowest: compounds 1, 2 and 3 (each within the scatter of the next, the first and the last beyond it).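

In this assay, the change from phenoxy to 4-methylphenoxy gives a 1.2-fold higher number from compound 2 to compound 3 (0.06 log units; within the scatter), so a methyl on this aromatic carbon leaves the read-out within the scatter. Compound 3 also isolates the other difference from compound 1, hydrogen in place of methyl on an oxygen on a saturated carbon, which gives a 2.2-fold higher number from compound 1 to compound 3 (0.35 log units; beyond the scatter), a modest step beyond the scatter. Nothing available explains the size of either step. As far as these compounds go, whether a chlorine or an amine on that aromatic carbon would read the same stays open, as does the effect of a longer chain on that oxygen.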